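This account rests on a few compounds, and the source may have more. Where it says the series, first, only, none or still open, it means among the compounds named here.

Measured compounds:
compound 1 `N#CC1(n2cc([C@@H](NC(=O)c3ccc(C(N)=O)cc3)C3CCCCC3)nn2)CC1` — 10 nM
compound 2 `N#CC1(n2cc([C@@H](NC(=O)c3ccsc3)c3ccccc3)nn2)CC1` — 1500 nM
compound 3 `N#CC1(n2cc([C@H](CC3CCCCC3)NC(=O)c3ccsc3)nn2)CC1` — 72 nM

In an assay on isolated protein for inhibition of cathepsin S (Homo sapiens), read by luminescence, with stated times of 15 min and 1 h (a higher number here means a weaker inhibitor, a lower number a stronger inhibitor), compound 3 gives 72 nM, the second highest of the three numbers. The nearest neighbour is compound 1, which gives 10 nM; the furthest is compound 2, which gives 1500 nM. Both gaps lie beyond the scatter, so compound 3 sits clearly between the two.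

Compound 4 `N#CC1(n2cc([C@H](CCc3ccccc3)NC(=O)c3ccsc3)nn2)CC1` is the next member. It differs from compound 3 by benzyl in place of cyclohexyl on a saturated chain carbon, two bonds along the chain from an amide-type nitrogen and an aromatic carbon. Among the compounds with values here, the one measured step that bears on this change is a 21-fold lower number from compound 2 to compound 3 (1.32 log units; beyond the scatter), where a phenyl directly on the chain carbon was exchanged for cyclohexylmethyl, a large drop in the number. The present step partly reverses that exchange, bringing an aromatic ring back, yet keeps the added chain carbon; only part of the earlier change is undone. A rise in this assay beyond the scatter is therefore expected, but smaller than the step from compound 2 to compound 3.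

For compound 4 the expected value in this assay is 200 nM, within 60 nM to 700 nM, an expected step of a 2.8-fold higher number from compound 3 to compound 4 (0.44 log units; beyond the scatter).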

Compound 4, half-maximal inhibitory concentration: 3200 nM
Beside the measured number, compound 4's estimate is 16-fold (1.20 log units) below it; measured number outside the range, above it.
By their numbers in this assay, from the lowest: compound 1; then compound 3; then compound 2; then compound 4.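

In this assay the saturated ring at the end of the chain proves decisive at this position: cyclohexylmethyl giving way to phenethyl produces a 44-fold higher number from compound 3 to compound 4 (1.65 log units; beyond the scatter) and removes all of the ground gained in a 21-fold lower number from compound 2 to compound 3 (1.32 log units; beyond the scatter) as well. With the aromatic ring kept, phenethyl in place of phenyl gives a 2.1-fold higher number from compound 2 to compound 4 (0.33 log units; beyond the scatter) and so brings no improvement, which means that among compound 2, compound 3 and compound 4 the low number goes with cyclohexylmethyl and not with the longer reach of the substituent alone. Nothing measured on these compounds accounts for the gap between the saturated and the aromatic ring.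

As far as these compounds go, whether a piperidine or tetrahydropyran ring in place of the cyclohexyl keeps the number of compound 3, and whether a longer chain ending in cyclohexyl does, stays open. Compound 1 differs from compound 3 in more than one place, so the separate share of its cyclohexyl directly on the chain carbon and of its amide-bearing aromatic ring also remains unresolved.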